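The source may hold more compounds than are shown below. What is called first, only, known or untested is meant among the compounds shown, and "the series" means these compounds.

Measured so far in a functional assay on A9L-m1 cells with A9 (Mus musculus) as the target; on this read-out higher numbers stand for an effect only at larger amounts of compound and lower numbers for an effect already at smaller amounts 
- compound 1 `Clc1nccnc1C1CN2CCC1CC2` gives 1590000 nM 
- compound 2 `CCCCCCOc1nccnc1[C@@H]1CN2CCC1CC2` gives 360000 nM 

Compound 1 holds the higher of the two numbers, at 1590000 nM in this series, so it needs the larger amount of compound for an effect. The gap down to compound 2 lies beyond the usual scatter.

Compound 3 `CCCCCCSc1nccnc1C1CN2CCC1CC2` has hexylsulfanyl in place of chloro on an aromatic carbon of the core of compound 1 (hexylsulfanyl in place of chloro on an aromatic carbon). The new group sits on that carbon, next to the ring nitrogen.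

Among the measured compounds shown here, no measured pair differs in one place only, so the expectation rests on thin data. A step down in this assay, beyond the scatter, is expected for compound 3. For the measured compounds named here, its likely size is close to the gap between the two measured numbers, with compound 2 at 360000 nM as the only guide. The expected change is a 6.4-fold lower number from compound 1 to compound 3 (0.80 log units; beyond the scatter) in this read-out. The estimate for compound 3 is 250000 nM within a range of 60000 nM to 900000 nM for now.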

Compound 3, half-maximal effective concentration: 270000 nM
Compound 3: the middle estimate sits 1.1-fold (0.03 log units) below what was measured; measured number inside the range.
By their numbers in this assay, from the lowest: compounds 3 and 2 (each within the scatter of the next); then compound 1.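

Among the compounds shown here, the change from chloro to hexylsulfanyl gives the first one-place step: in this assay there is a 5.9-fold lower number from compound 1 to compound 3 (0.77 log units; beyond the scatter), a modest move that lies beyond the scatter. This shows that the aromatic carbon next to the ring nitrogen accepts a group of seven heavy atoms in place of a single chlorine, and that the number falls rather than rises with this change, with compound 3 at 270000 nM. No measurement on hand gives a reason for this step.

A single pair cannot separate the contribution of the sulfur from that of the six-carbon chain, and it gives no trend with chain length, so a shorter methylsulfanyl or a longer octylsulfanyl on the same carbon remains the obvious open comparison. Going by these compounds, it also remains open whether an amine or a carboxylic acid at this position would shift the number in the same direction as hexylsulfanyl, or whether the step seen here is specific to that group.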